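The compounds below may be only part of what the source reports. "The series", "measured", "known", "first", "only" and "open" are said of these compounds alone.

Compound 1 `Oc1cccc(-c2cc(-c3cccc(C(F)(F)F)c3)cc(-c3ccccc3O)n2)c1`: 19500 nM
Compound 2 `Oc1ccc(-c2cc(-c3cccc(C(F)(F)F)c3)cc(-c3ccccc3O)n2)cc1`: > 50000 nM
Compound 3 `Oc1ccc(-c2cc(-c3cccc(C(F)(F)F)c3)cc(-c3ccc(O)cc3)n2)cc1`: > 50000 nM

All three compounds were tested in a functional assay on HeLa cells (Homo sapiens) for inhibition; a higher number here means a weaker inhibitor, a lower number a stronger inhibitor. Compound 1 gives a numerical reading, 19500 nM. The value of compound 2 is a limit of the assay, not a number. The value of compound 3 is likewise a limit. Compound 2 therefore stands at the limit of > 50000 nM in this assay, at which 2 of the 3 values shown sit. The first step, an at least 2.5-fold higher number from compound 1 to compound 2 (0.40 log units; beyond the scatter), carries the reading from a number up to that limit. The second step, a step that the two limits leave unreadable from compound 2 to compound 3, runs between two limits.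

Compound 4 `Oc1ccc(-c2cc(-c3cccc(OC(F)(F)F)c3)cc(-c3ccccc3O)n2)cc1` differs from compound 2 in one place: trifluoromethoxy in place of trifluoromethyl on an aromatic carbon. Among the compounds with values here, both measured steps move a hydroxyl group from one position to another on a ring; neither touches the trifluoromethyl group, so no measured step bears directly on this change. With compound 2 resting at the limit of > 50000 nM in this assay, at which 2 of the 3 values shown sit, compound 4 is expected to stay in the same region, so the estimated step is a number no higher from compound 2 to compound 4 (the limit leaves the size open). The estimate for compound 4 is 50000 nM, with a range from 15000 nM to 150000 nM, and a limit rather than a number is the likelier outcome.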

Compound 4, half-maximal inhibitory concentration: > 50000 nM
Compound 4 gave a limit, no number; the forecaster's own chance of this, stated with the estimate: 65%; the middle value lies on the limit itself.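

Compound 2 and compound 4 each give a limit of the assay rather than a number, and the step between them cannot be read: the limit of > 50000 nM in this assay, at which 3 of the 4 values shown sit.

The compounds shown leave open whether trifluoromethoxy in place of trifluoromethyl changes inhibition at all.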